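Swapping a Small Ring for a Hydroxylated Larger One

This account rests on a few compounds, and the source may have more. Where it says the series, first, only, none or still open, it means among the compounds named here.

Compound 1 `c1ccc(Cn2nnc3c(NC4CC4)nc(-c4ccccc4)nc32)cc1`: 11000000 nM
Compound 2 `CCNc1nc(-c2ccccc2)nc2c1nnn2Cc1ccccc1Cl`: 463000000 nM
Compound 3 `Clc1ccccc1Cn1nnc2c(NC3CCCCC3)nc(-c3ccccc3)nc21`: 34000000 nM

Of the compounds shown here, three sharing one core have been tested in an assay on isolated protein for binding affinity to adenosine receptor A1 (Bos taurus); on this read-out lower numbers stand for stronger inhibition and higher numbers for weaker inhibition. Compound 1 gives the lowest of the three numbers, with compound 3 nearest and compound 2 furthest away. Among the compounds with values here, the only single-point comparison available is a 14-fold lower number from compound 2 to compound 3 (1.13 log units; beyond the scatter), where a larger ring on the aromatic nitrogen brought a markedly lower number.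

Compound 4 `OC1CCC(Nc2nc(-c3ccccc3)nc3c2nnn3Cc2ccccc2)CC1` differs from compound 1 by 4-hydroxycyclohexyl in place of cyclopropyl on a nitrogen on an aromatic ring. Within the data shown here, since the one comparison at this position rewarded a larger ring, a modest move toward a lower number is expected, tempered by the absence of any measured hydroxyl-bearing group here. Compound 4 is therefore estimated at 5000000 nM, within 1000000 nM to 30000000 nM, an expected step of a 2.2-fold lower number from compound 1 to compound 4 (0.34 log units; beyond the scatter).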

Compound 4, inhibition constant: 2700000 nM
Compound 4: middle estimate off by 1.9-fold (0.27 log units), on the high side, within the range that was stated.
By their numbers in this assay, from the lowest: compound 4; then compound 1; then compound 3; then compound 2.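

Within the data shown here, at this nitrogen, the step of a 4.1-fold lower number from compound 1 to compound 4 (0.61 log units; beyond the scatter) shows that a ring carrying a hydroxyl group can go with a lower number in this assay, something the earlier compounds could not show. This change enlarges the ring and adds the hydroxyl at once, so the two contributions cannot be told apart. No measured evidence bears on the reason for this step. Still open, as far as these compounds go, is how much belongs to the hydroxyl alone, which a plain cyclohexyl on the core of compound 1 would help separate. Also open, from the compounds shown here alone, is whether an amine or a methoxy group in the hydroxyl's place would give a similar number.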